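The source may report more compounds than this note shows. Statements on the series, on what has been measured and on what is new or still open speak of the compounds shown alone.

Of the compounds shown here, three built on one shared core have been tested in a functional assay on the whole organism (strain albino) for inhibition, with Rattus norvegicus as the target, read by paw edema, with stated times of 1 h and 3 h, at a dose of 25 mg/kg by the oral route; a higher number here means more inhibition at the dose given (going by the name of the read-out), a lower number less inhibition. Compound 1 `CC1=C(C(=O)Nc2ccc(F)cc2)C(c2ccc(Br)cc2)n2c(s/c(=C/c3ccccc3)c2=O)=N1` gives 5% in this assay, and compound 2 `CC1=C(C(=O)Nc2ccc(F)cc2)C(c2ccc([N+](=O)[O-])cc2)n2c(s/c(=C/c3ccc(Cl)cc3Cl)c2=O)=N1` gives 17%. Compound 3 `CC1=C(C(=O)Nc2ccc(F)cc2)C(c2ccc(Cl)cc2)n2c(s/c(=C/c3ccc(Br)cc3)c2=O)=N1` gives 35%, the highest of the three numbers: its lead over compound 2 and its larger lead over compound 1 both lie beyond the usual scatter. Compound 4 `CC1=C(C(=O)Nc2ccc(F)cc2)C(c2ccc(Cl)cc2)n2c(s/c(=C/c3ccccc3[N+](=O)[O-])c2=O)=N1` is the untested neighbour of compound 3, changed at one place: 2-nitrophenyl in place of 4-bromophenyl on a double-bonded chain carbon bound to an aromatic carbon. Going by the values given here, no measured pair of compounds isolates this exact change, so the step is open. Compound 4 is expected to show a modest fall in this assay, estimated as a number 10 percentage points lower from compound 3 to compound 4 (within the scatter), possibly none beyond the scatter. The estimate for compound 4 is 25%, with a range from 8% to 42%.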

Compound 4, a percentage reported as inhibition, in the whole organism at one dose (the size of the read-out at that dose, not a potency): 16%
Compound 4: the middle estimate sits 9 percentage points above what was measured, within the range that was stated.
By their numbers in this assay, from the lowest: compound 1; then compounds 4 and 2 (each within the scatter of the next); then compound 3.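

Going by these compounds alone, compound 3 and compound 4 are the first pair here to differ in one place only, so they isolate a change on the double-bonded chain carbon bound to an aromatic carbon. In this assay, 2-nitrophenyl in place of 4-bromophenyl gives a number 19 percentage points lower from compound 3 to compound 4 (beyond the scatter), which shows that the group held at this place affects the read-out. No supporting measurement explains this fall.

From the compounds shown here alone, it remains open whether other groups here would keep or lose the inhibition, such as an amine or a carboxylic acid on the aromatic ring. A single pair also cannot show whether the same step would hold on a different core.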